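Hydroxy to benzoyloxy from compound 1 to compound 3

The compounds below may be only part of what the source reports. "The series", "measured", "known", "first", "only" and "open" are said of these compounds alone.

Among the measured compounds shown here, in an ADME assay on Hepa 59T/VGH cells (Homo sapiens) for cytotoxicity, read by MTT assay (a lower number here means that less compound is needed, a higher number that more compound is needed for the effect), compound 1 `C=C1CCCC(C)(C)[C@@H]1C[C@H](O)/C(C)=C/CC[C@@H]1[C@@]2(C)CCCC(C)(C)[C@@H]2CC[C@@]1(C)O` gives 5.7 ug/mL, the only actual number so far.

Compound 2 `C=C1CCCC(C)(C)[C@@H]1C[C@@H](O)/C(C)=C/CC[C@@H]1[C@@]2(C)CCCC(C)(C)[C@@H]2CC[C@@]1(C)O` is reported only as a limit, > 10 ug/mL.

For the measured compounds named here, the sole measured step is an at least 1.7-fold higher number from compound 1 to compound 2 (0.24 log units; that floor lies within the scatter). It rests on (the limit of > 10 ug/mL in this assay, at which 1 of the 2 values shown sits), so its true size is open, and on (the fact that compounds 1 and 2 differ only in the configuration as drawn), so it changes no atoms or bonds.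

Compound 3 `C=C1CCCC(C)(C)[C@@H]1C[C@H](OC(=O)c1ccccc1)/C(C)=C/CC[C@@H]1[C@@]2(C)CCCC(C)(C)[C@@H]2CC[C@@]1(C)O` keeps the core of compound 1 and carries benzoyl in place of hydrogen on an oxygen on a saturated carbon, a change of hydroxy to benzoyloxy: benzoyl in place of hydrogen on an oxygen on a saturated carbon. Going by the values given here, no measured step involves a change of this kind, so the data give no direction for it.

The working expectation therefore stays anchored on compound 1 at 5.7 ug/mL, with no step beyond the scatter expected in this assay but with wide uncertainty.

The estimated step is a 1.1-fold higher number from compound 1 to compound 3 (0.02 log units; within the scatter).

Compound 3 is expected at 6 ug/mL, with an estimated range of 2.5 ug/mL to 14 ug/mL.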

Compound 3, concentration for half-maximal effect: > 10 ug/mL
Compound 3: only a limit was reported (the forecaster's own chance of this, stated with the estimate: 35%); at least 1.6-fold (0.22 log units) between middle value and limit.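

Replacing hydrogen with benzoyl on this oxygen gives, in this assay, an at least 1.7-fold higher number from compound 1 to compound 3 (0.24 log units; that floor lies within the scatter), and the size of the true step stays open: the limit of > 10 ug/mL in this assay, at which 2 of the 3 values shown sit.

Compound 3 is reported only as a limit, > 10 ug/mL.

Among the compounds shown here, this is the first change of atoms at this oxygen, whereas the earlier step from the other compound pair changed only the configuration as drawn, and it yields no second actual number, so compound 1 at 5.7 ug/mL remains the only compound with one.

The series therefore cannot yet say whether the free hydroxy matters for the read-out, nor whether a real change in this assay lies behind this step, since its floor stays within the scatter. Going by these compounds, whether a smaller acetyl group or a methyl ether on this oxygen, or an amine in place of the hydroxy, would give an actual number near that of compound 1 remains open, as does the outcome of benzoyl on the other configuration at this carbon.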